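The compounds below may be only part of what the source reports. "The series", "measured", "known", "first", "only" and "open" are said of these compounds alone.

In a functional assay on A549 cells (Homo sapiens) for antiproliferative activity, read by MTT assay, with a stated time of 72 h (on this read-out higher numbers stand for weaker inhibition and lower numbers for stronger inhibition), compound 1 `CCOc1ccc(-c2sc(N(C)C)nc2-c2cc(OC)c(OC)c(OC)c2)cc1` gives > 10000 nM, which is a limit and not a number. Compound 2 `COc1cc(-c2nc(C)sc2-c2ccc(C)cc2)cc(OC)c1OC` gives 1950 nM, and compound 3 `COc1cc(-c2nc(C)sc2-c2ccc(C(F)(F)F)cc2)cc(OC)c1OC` gives 4290 nM, the higher of the two actual numbers. Compound 4 `CCOc1ccc(-c2sc(C)nc2-c2cc(OC)c(OC)c(OC)c2)cc1` has ethoxy in place of trifluoromethyl on an aromatic carbon. Among the compounds with values here, only one measured step touches this place: a 2.2-fold higher number from compound 2 to compound 3 (0.34 log units; beyond the scatter), a modest one on replacing methyl with trifluoromethyl. Compound 1 also carries ethoxy but differs elsewhere too, so it offers no clean comparison. With so little to go on, a modest move towards stronger inhibition is expected, estimated as a 3.6-fold lower number from compound 3 to compound 4 (0.55 log units; beyond the scatter). For compound 4 the estimated value is 1200 nM, with an expected range of 150 nM to 6000 nM.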

Compound 4, half-maximal inhibitory concentration: 3320 nM
Beside the measured number, compound 4's estimate is 2.8-fold (0.44 log units) below it, and the stated range covers the measured number.
By their numbers in this assay, from the lowest: compounds 2, 4 and 3 (each within the scatter of the next, the first and the last beyond it). At a limit, above all of these: compound 1.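

Ethoxy in place of trifluoromethyl on this aromatic carbon gives a 1.3-fold lower number from compound 3 to compound 4 (0.11 log units; within the scatter), and ethoxy in place of methyl gives a 1.7-fold higher number from compound 2 to compound 4 (0.23 log units; within the scatter), so in this assay ethoxy cannot be told apart from either group. The place occupied by methyl in compound 4 shows a clearer effect, since methyl in place of dimethylamino gives an at least 3.0-fold lower number from compound 1 to compound 4 (0.47 log units; beyond the scatter). That step starts from a limit and not a number: the limit of > 10000 nM in this assay, at which 1 of the 4 values shown sits.

Still open, from the compounds shown here alone, is whether an amine, a carboxylic acid or a longer chain on the aromatic carbon would shift the number further. Also open, going by these compounds, is how other groups would behave in place of that methyl.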